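Solubility of cyclobutyl hydroxamate and a serine-derived analogue

The source may report more compounds than this note shows. Statements on the series, on what has been measured and on what is new or still open speak of the compounds shown alone.

Compound 1 `O=C(NC1(C(=O)NO)CCC1)c1ccc(C#Cc2ccccc2)cc1` carries the hydroxamic acid on a four-membered carbocycle. In a physicochemical assay for solubility (on this read-out higher numbers stand for higher solubility and lower numbers for lower solubility), compound 1 gives 5000 nM, the higher of the two numbers recorded so far. Compound 3 `O=C(NC1(C(=O)NO)CCSCC1)c1ccc(C#Cc2ccccc2)cc1` gives 1000 nM in this assay. Compound 2 `O=C(NC1(C(=O)NO)CCN(Cc2ccccc2)CC1)c1ccc(C#Cc2ccccc2)cc1` returns only a limit of the assay, < 1000 nM, and not a number; it sits at the limit of < 1000 nM in this assay, at which 1 of the 3 values shown sits. Within the data shown here, no step between compounds differing in one place has been measured, so nothing quantifies any single change.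

Compound 4 `O=C(N[C@@H](CO)C(=O)NO)c1ccc(C#Cc2ccccc2)cc1` has not yet been measured in this assay. It differs from compound 1 in one place: a group of 7 heavy atoms (3 carbon, 1 nitrogen, 3 oxygen; no ring) in place of a group of 8 heavy atoms (5 carbon, 1 nitrogen, 2 oxygen; one four-membered non-aromatic ring of carbon only), on an amide-type nitrogen. Among the measured compounds shown here, since no comparable step has been measured, the expectation rests on the values of compound 1 and compound 3 alone. Compound 4 is expected to give 12000 nM, with a range from 3500 nM to 40000 nM. This would correspond to an expected step of a 2.4-fold higher number from compound 1 to compound 4 (0.38 log units; beyond the scatter), a modest rise beyond the usual scatter, with the possibility that the value stays close to that of compound 1.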

Compound 4, solubility: 28000 nM
For compound 4 the middle estimate is 2.3-fold (0.37 log units) below the measured one, within the range that was stated.
By their numbers in this assay, from the lowest: compound 3; then compound 1; then compound 4.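

Working notes: in this assay, the open-chain group with one defined stereocentre replacing 1-(hydroxycarbamoyl)cyclobutyl on the amide-type nitrogen gives a 5.6-fold higher number from compound 1 to compound 4 (0.75 log units; beyond the scatter). Among these compounds, this is the first single-place step, and it shows that the read-out responds to a change at this position and that the four-membered ring of compound 1 is not needed to reach a measured number in this range. Nothing measured among the compounds shown accounts for the size of this step.

Among the compounds shown here, the single step changes the ring, the oxygen count and the stereocentre together, so their separate contributions remain unresolved. Also open, on these data alone, is how the read-out would respond at this position to a plain methyl side chain, a primary amine or a carboxylic acid on the open chain, or to the opposite stereoisomer of compound 4.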